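A few compounds are considered here, and "the series" means these few. Any claim that something is new, unique, unknown or untested is made for them only; others in the source may bear on it.

Measured so far in a functional assay on QGY-7703 cells (Homo sapiens) for cytotoxicity, read by MTT assay, with a stated time of 24 h; a lower number here means a stronger inhibitor, a higher number a weaker inhibitor:
- compound 1 `CN1C/C(=C\c2cccnc2)C(=O)/C(=C/c2ccc(F)cc2Br)C1`: 2610 nM
- compound 2 `CN1C/C(=C\c2cccnc2)C(=O)/C(=C/c2ccccc2C(F)(F)F)C1`: 2910 nM

Compound 1 and compound 2 lie within the scatter of each other, so compound 1 does not stand apart on these numbers. Compound 3 `CN1C/C(=C\c2ccc(C#N)cc2)C(=O)/C(=C/c2cccnc2)C1` is still unmeasured. Its difference from compound 1 is 4-cyanophenyl in place of 2-bromo-4-fluorophenyl on a double-bonded chain carbon bound to a double-bonded ring carbon, that is, 4-cyanophenyl in place of 2-bromo-4-fluorophenyl. Among the measured compounds shown here, no measured pair isolates this change, so no step beyond the scatter is expected in this assay, and no direction is favoured. The expected step is a 1.1-fold higher number from compound 1 to compound 3 (0.06 log units; within the scatter). Compound 3 is estimated at 3000 nM, with an expected range of 1000 nM to 9000 nM.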

Compound 3, half-maximal inhibitory concentration: > 20000 nM
Compound 3 gave a limit, no number (the forecaster's own chance of this, stated with the estimate: 5%); middle value at least 6.6-fold (0.82 log units) away from the limit.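

In this assay compound 3 gives > 20000 nM, which is a limit of the assay and not a number. Swapping the 2-bromo-4-fluorophenyl group for a 4-cyanophenyl group gives an at least 7.6-fold higher number from compound 1 to compound 3 (0.88 log units; beyond the scatter), the first separation beyond the scatter here, whereas compound 1 and compound 2 lie within it, so this position is not indifferent to the group it carries. The size of this step rests on a limit: the limit of > 20000 nM in this assay, at which 1 of the 3 values shown sits.

Whether the loss of bromine and fluorine or the entry of the nitrile matters remains open, as no compound shown separates them. On these data alone, how an amine or a carboxylic acid at this position would read in this assay also remains open.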